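A few compounds are considered here, and "the series" means these few. Any claim that something is new, unique, unknown or untested is made for them only; others in the source may bear on it.

Within the data shown here, compound 3 `Cc1nn(C)c(N(C)C)c1/C=N/OCc1ccc(C(=O)OC(C)(C)C)cc1` is one of three compounds measured in a functional assay on SK-MEL-2 cells (Homo sapiens) for cytotoxicity (a lower number here means a stronger inhibitor, a higher number a weaker inhibitor), where compound 3 gives 23.9 ug/mL. The other two carry different groups at the same place on the shared core. Compound 1 `Cc1nn(C)c(-n2ccc3ccccc32)c1/C=N/OCc1ccc(C(=O)OC(C)(C)C)cc1` gives 26.5 ug/mL in this assay, and compound 2 `Cc1nn(C)c(Oc2ccc(Cl)cc2)c1/C=N/OCc1ccc(C(=O)OC(C)(C)C)cc1` gives 18.8 ug/mL. All three numbers lie within the scatter of one another: a 1.1-fold lower number from compound 1 to compound 3 (0.04 log units; within the scatter), a 1.3-fold higher number from compound 2 to compound 3 (0.10 log units; within the scatter) and a 1.4-fold lower number from compound 1 to compound 2 (0.15 log units; within the scatter). Compound 3 therefore stands among values that cannot be told apart.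

Compound 4 `Cc1nn(C)c(Sc2ccccc2)c1/C=N/OCc1ccc(C(=O)OC(C)(C)C)cc1` is not yet measured. It differs from compound 3 in one place: phenylsulfanyl in place of dimethylamino on an aromatic carbon. Among the measured compounds shown here, the steps that bear on this change are the two that replace a larger group at the same aromatic carbon with dimethylamino, a 1.1-fold lower number from compound 1 to compound 3 (0.04 log units; within the scatter) and a 1.3-fold higher number from compound 2 to compound 3 (0.10 log units; within the scatter), and neither moved the number beyond the scatter. Three unlike groups at this carbon gave numbers within the scatter, so the step to phenylsulfanyl is expected to be a 1.1-fold lower number from compound 3 to compound 4 (0.04 log units; within the scatter), with no direction that can be claimed. Compound 4 is accordingly estimated to give 22 ug/mL in this assay, in a range from 11 ug/mL to 45 ug/mL.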

Compound 4, half-maximal inhibitory concentration: 4.91 ug/mL
Compound 4: middle estimate off by 4.5-fold (0.65 log units), on the high side; the whole stated range lies above it.
By their numbers in this assay, from the lowest: compound 4; then compounds 2, 3 and 1 (each within the scatter of the next).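

Phenylsulfanyl is the first group at this aromatic carbon to stand apart in this assay: the change from dimethylamino gives a 4.9-fold lower number from compound 3 to compound 4 (0.69 log units; beyond the scatter), and the steps from the two other groups agree, with a 3.8-fold lower number from compound 2 to compound 4 (0.58 log units; beyond the scatter) and a 5.4-fold lower number from compound 1 to compound 4 (0.73 log units; beyond the scatter). The position therefore does respond to what it carries, even though the three earlier groups could not be told apart, and an aromatic ring at this carbon is not enough on its own, since compound 1 and compound 2 both carry one and stay within the scatter of compound 3. No measurement is at hand that would explain this step.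

Compound 2 differs from compound 4 both in the atom that links the six-membered ring to the core and in the chlorine on that ring, so these compounds cannot show which of the two matters; phenoxy and 4-chlorophenylsulfanyl would separate them. Methylsulfanyl would keep the sulfur link without the phenyl ring. Its number would show whether the lower number remains without that ring.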